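Side-chain change from compound 3 to compound 4

A few compounds are considered here, and "the series" means these few. Any claim that something is new, unique, unknown or untested is made for them only; others in the source may bear on it.

In a functional assay on a cell-free system (plasma, Homo sapiens), with a stated time of 3 min (on this read-out higher numbers stand for weaker inhibition and lower numbers for stronger inhibition), compound 3 `CC1(C[C@@H](O)C(=O)N2C[C@H]3C[C@H]3[C@H]2C(=O)NCc2cc(Cl)ccc2-n2cnnn2)CC1` gives 500 nM. This is within the scatter of compound 2 `CCCC[C@@H](O)C(=O)N1C[C@H]2C[C@H]2[C@H]1C(=O)NCc1cc(Cl)ccc1-n1cnnn1` at 750 nM, and both numbers lie beneath that of compound 1 `O=C(NCc1cc(Cl)ccc1-n1cnnn1)[C@@H]1[C@@H]2C[C@@H]2CN1C(=O)[C@H](O)Cc1ccccn1` at 1700 nM.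

Compound 4 `O=C(NCc1cc(Cl)ccc1-n1cnnn1)[C@@H]1[C@@H]2C[C@@H]2CN1C(=O)[C@H](O)c1ccccc1F` differs from compound 3 on a saturated chain carbon bound to a carbonyl carbon and an oxygen on a saturated carbon: 2-fluorophenyl in place of (1-methylcyclopropyl)methyl on a saturated chain carbon bound to a carbonyl carbon and an oxygen on a saturated carbon.

Among the measured compounds shown here, no measured compound carries 2-fluorophenyl at this place. The closest evidence is the pyridin-2-yl of compound 1, which sits on a saturated chain carbon two bonds along the chain from a carbonyl carbon and an oxygen on a saturated carbon. Two modest steps bear on it: a 2.3-fold lower number from compound 1 to compound 2 (0.36 log units; beyond the scatter) and a 3.4-fold lower number from compound 1 to compound 3 (0.53 log units; beyond the scatter). The alkyl comparison, a 1.5-fold lower number from compound 2 to compound 3 (0.18 log units; within the scatter), shows no separation.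

An aromatic ring therefore points, weakly, toward a higher number in this assay. The expected step is a 1.6-fold higher number from compound 3 to compound 4 (0.20 log units; within the scatter), and a move beyond the scatter is not expected. For compound 4 the estimated value is 800 nM, with an expected range of 200 nM to 2500 nM.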

Compound 4, half-maximal inhibitory concentration: 580 nM
Compound 4: the middle estimate sits 1.4-fold (0.14 log units) above what was measured; low and high end bracket the measured number.
By their numbers in this assay, from the lowest: compounds 3, 4 and 2 (each within the scatter of the next); then compound 1.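

In this assay, an aromatic ring at this place does not by itself separate from the alkyl groups: the 2-fluorophenyl of compound 4 stands level with the (1-methylcyclopropyl)methyl of compound 3 (a 1.2-fold higher number from compound 3 to compound 4 (0.06 log units; within the scatter)) and with the butyl of compound 2 (a 1.3-fold lower number from compound 2 to compound 4 (0.11 log units; within the scatter)). Only compound 1 stands apart (a 2.9-fold lower number from compound 1 to compound 4 (0.47 log units; beyond the scatter)), so among these four compounds the higher number goes with (pyridin-2-yl)methyl and not with aromatic rings in general. No measurement shown explains this difference.

Open, on these data alone, is whether the number of compound 1 follows the ring nitrogen or the methylene link, which a pyridin-2-yl placed directly on this carbon or a benzyl group would separate. Also open, as far as these compounds go, is whether an unsubstituted phenyl, or a phenyl carrying an amine or a carboxylic acid, stays level with compound 4.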